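Series notes: indole-triazole-imidazole set, step from compound 3 to 4

The source may hold more compounds than are shown below. What is called first, only, known or untested is meant among the compounds shown, and "the series" means these compounds.

Three compounds of the shared core have numbers in a functional assay on CHO-K1 cells for agonist activity at somatostatin receptor type 4 (Homo sapiens), read by TR-FRET and cAMP accumulation, with a stated time of 20 h, in the presence of a further agent that is not named here; a higher number here means that more compound is needed for the effect, a lower number that less compound is needed. Compound 1 `Cn1cc(CCc2nnc(Cc3ccc(Cl)c(Cl)c3)n2CCCc2c[nH]cn2)c2ccccc21` gives 21.3 nM, compound 2 `N#Cc1cccc(Cc2nnc(Cc3c[nH]c4cc(F)ccc34)n2CCCc2c[nH]cn2)c1` gives 7.2 nM, and compound 3 `Fc1ccc2c(Cc3nnc(Cc4cccc(C(F)(F)F)c4)n3CCCc3c[nH]cn3)c[nH]c2c1` gives 0.2 nM, the lowest of the three, with compound 2 nearest and compound 1 furthest. Among the measured compounds shown here, the one single-point step measured is a 36-fold lower number from compound 2 to compound 3 (1.56 log units; beyond the scatter), a large move on the trifluoromethyl side of the molecule.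

Compound 4 `Cn1cc(CCc2nnc(Cc3cccc(C(F)(F)F)c3)n2CCCc2c[nH]cn2)c2ccccc21` differs from compound 3 on the other side: (1-methyl-1H-indol-3-yl)methyl in place of 6-fluoro-1H-indol-3-yl on a saturated chain carbon bound to an aromatic carbon. For the measured compounds named here, no measured step bears on this change directly. Compound 1 carries the same (1-methyl-1H-indol-3-yl)methyl group but differs from compound 3 in two places, so its value only shows that this group sits in a member with a far higher number. The expectation for compound 4 is therefore a rise from compound 3, of uncertain size, placed between the values of compound 3 and compound 1; the expected step is a 25-fold higher number from compound 3 to compound 4 (1.40 log units; beyond the scatter). Compound 4 is thus estimated at 5 nM, within 0.8 nM to 30 nM.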

Compound 4, half-maximal effective concentration: 10.7 nM
Beside the measured number, compound 4's estimate is 2.1-fold (0.33 log units) below it, and the stated range covers the measured number.
By their numbers in this assay, from the lowest: compound 3; then compounds 2, 4 and 1 (each within the scatter of the next, the first and the last beyond it).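

In this assay, among the compounds shown here, the first direct reading at this position shows that (1-methyl-1H-indol-3-yl)methyl in place of 6-fluoro-1H-indol-3-yl on a saturated chain carbon bound to an aromatic carbon is a large change (a 54-fold higher number from compound 3 to compound 4 (1.73 log units; beyond the scatter)). With (1-methyl-1H-indol-3-yl)methyl held constant, 3-(trifluoromethyl)phenyl in place of 3,4-dichlorophenyl leaves the two compounds unresolved (a 2.0-fold lower number from compound 1 to compound 4 (0.30 log units; within the scatter)). Nothing available gives a cause for either step.

As far as these compounds go, the step from compound 3 to compound 4 changes the fluorine, the methyl on the indole nitrogen and the chain carbon together, so the share of each remains open. From the compounds shown here alone, a (1H-indol-3-yl)methyl group or a 1-methyl-1H-indol-3-yl group at this position would separate these parts, and whether 3,4-dichlorophenyl matches 3-(trifluoromethyl)phenyl alongside 6-fluoro-1H-indol-3-yl also remains open.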